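From thiophen-2-yl to phenyl on an aromatic carbon

The source may report more compounds than this note shows. Statements on the series, on what has been measured and on what is new or still open speak of the compounds shown alone.

Measured in a functional assay on K562 cells (Homo sapiens), read by MTT assay, with a stated time of 72 h; on this read-out lower numbers stand for stronger inhibition and higher numbers for weaker inhibition:
- compound 1 `O=c1[nH]cnc2c1c(-c1ccccc1)cn2[C@@H]1O[C@H](CO)[C@@H](O)[C@H]1O` gives > 20000 nM
- compound 2 `COc1nc(N)nc2c1c(-c1cc3ccccc3o1)cn2[C@@H]1O[C@H](CO)[C@@H](O)[C@H]1O` gives 15500 nM
- compound 3 `Nc1nc2c(c(-c3cccs3)cn2[C@@H]2O[C@H](CO)[C@@H](O)[C@H]2O)c(=O)[nH]1` gives 16800 nM

The entry of compound 1 is a limit of the assay and not a number. This is the limit of > 20000 nM in this assay, at which 1 of the 3 values shown sits. The two true numbers lie close together, since compound 3 at 16800 nM and compound 2 at 15500 nM are within the scatter of each other in this assay.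

The next compound, compound 4 `Nc1nc2c(c(-c3ccccc3)cn2[C@@H]2O[C@H](CO)[C@@H](O)[C@H]2O)c(=O)[nH]1`, is reached from compound 3 by putting phenyl in place of thiophen-2-yl on an aromatic carbon. Within the data shown here, no measured pair in this small set isolates a single change, so the size of this step has to be judged without a direct precedent. A shift in neither direction beyond the scatter is expected, given compound 3 at 16800 nM. The expected step is a 1.1-fold higher number from compound 3 to compound 4 (0.03 log units; within the scatter). For compound 4 the estimated value is 18000 nM, with an expected range from 9000 nM to 32000 nM.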

Compound 4, half-maximal inhibitory concentration: > 20000 nM
Compound 4 gave a limit, no number; the forecaster's own chance of this, stated with the estimate: 45%; middle value at least 1.1-fold (0.04 log units) away from the limit.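

In this assay, among these compounds, this is the first change in the set that can be read in one place, and putting phenyl in place of thiophen-2-yl on an aromatic carbon gives an at least 1.1-fold higher number from compound 3 to compound 4 (0.07 log units; that floor lies within the scatter). Compound 4 gives > 20000 nM, which is a limit of the assay and not a number, so only a floor is known for this step, and the true size of the change stays hidden. Compound 4 now shares this ceiling with compound 1, and the step between those two, amino in place of hydrogen, cannot be read: the limit of > 20000 nM in this assay, at which 2 of the 4 values shown sit.

From the compounds shown here alone, how far compound 4 actually lies from compound 3 remains open. Also open, going by these compounds, is whether a methyl group, a carboxylic acid or an aminomethyl group on this aromatic carbon would give a number clearly apart from that of compound 3.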